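One Group Swapped on a Carbonyl Carbon of Compound 3

This account rests on a few compounds, and the source may have more. Where it says the series, first, only, none or still open, it means among the compounds named here.

- Compound 1 `C=C(Cl)C(=O)Nc1cc(Nc2nc3c(c(-c4cn(C)c5ccc(F)cc45)n2)CSCC3)c(OC)cc1N(C)CCN(C)C`: 864 nM
- Compound 2 `COc1cc(N(C)CCN(C)C)c(NC(=O)C=C(C)C)cc1Nc1nc2c(c(-c3cn(C)c4ccc(F)cc34)n1)CSCC2`: 902 nM
- Compound 3 `COc1cc(N(C)CCN(C)C)c(NC(=O)C=C(C)C)cc1Nc1nc2c(c(-c3cn(C)c4ccccc34)n1)CSCC2`: 583 nM

All three compounds were measured in a functional assay on A549 cells (Homo sapiens) for inhibition, read by MTT assay, with a stated time of 72 h; on this read-out higher numbers stand for weaker inhibition and lower numbers for stronger inhibition. Compound 3 stands within the usual scatter of both other compounds, so its value does not set it apart from them. Compound 4 `COc1cc(N(C)CCN(C)C)c(NC(=O)/C=C\C(C)C)cc1Nc1nc2c(c(-c3cn(C)c4ccccc34)n1)CSCC2` keeps the rest of compound 3 and changes one group, on a carbonyl carbon whose other neighbour is an amide-type nitrogen: 3-methylbut-1-en-1-yl in place of 2-methylprop-1-en-1-yl on a carbonyl carbon. Neither group carries a ring or a charge.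

The closest guide is the other change on such a carbonyl carbon, 2-methylprop-1-en-1-yl in place of 1-chloroethenyl, which gave a 1.0-fold higher number from compound 1 to compound 2 (0.02 log units; within the scatter). The remaining measured step, a 1.5-fold lower number from compound 2 to compound 3 (0.19 log units; within the scatter), involves an aromatic carbon and bears on this change less directly. With both steps this small, no step beyond the scatter is expected in this assay, although one such comparison is thin evidence. The expected step is a 1.1-fold higher number from compound 3 to compound 4 (0.05 log units; within the scatter). For compound 4 the estimated value is 650 nM, with an expected range of 280 nM to 1500 nM.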

Compound 4, half-maximal inhibitory concentration: 788 nM
Beside the measured number, compound 4's estimate is 1.2-fold (0.08 log units) below it, and the stated range covers the measured number.
By their numbers in this assay, from the lowest: compounds 3, 4, 1 and 2 (each within the scatter of the next).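

On this carbonyl carbon, a group of 5 heavy atoms can take the place of one with 4 with little effect in this assay: 3-methylbut-1-en-1-yl in place of 2-methylprop-1-en-1-yl gives a 1.4-fold higher number from compound 3 to compound 4 (0.13 log units; within the scatter). Within the data shown here, until now, the only change measured at this position was on a core carrying fluoro, a 1.0-fold higher number from compound 1 to compound 2 (0.02 log units; within the scatter), whereas this one is on the core with hydrogen at that aromatic carbon, and it also stays within the scatter. Nothing shown here offers a measured explanation for the size of this step.

Both changes swap one open-chain alkenyl group for another, so they say little about groups of a different kind. On these data alone, whether a longer chain, a terminal amine or a carboxylic acid on this carbonyl carbon would shift the number beyond the scatter remains open.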